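The compounds below may be only part of what the source reports. "The series", "measured", "known", "first", "only" and "open" are said of these compounds alone.

Among the measured compounds shown here, in a functional assay on CHO cells with adenosine receptor A1 (Homo sapiens) as the target, read by cAMP accumulation and immunoassay, with a stated time of 6 min, tested at 10 uM (a lower number here means a stronger effect, a higher number a weaker effect of the compound at the concentration tested), compound 2 `Nc1scc(CN2CCN(CCCc3ccc(Cl)cc3)CC2)c1C(=O)c1ccc(Cl)cc1` gives -76%, the end point of the two numbers so far, while compound 1 `Nc1scc(CN2CCN(c3ccc(F)cc3Cl)CC2)c1C(=O)c1ccc(Cl)cc1` gives -70%, within the scatter of that. Compound 3 `Nc1scc(CN2CCN(c3cccc(Cl)c3)CC2)c1C(=O)c1ccc(Cl)cc1` differs from compound 2 in one place: 3-chlorophenyl in place of 3-(4-chlorophenyl)propyl on an amine nitrogen in a ring. For the measured compounds named here, one measured step bears on this, because it too changes the group on an amine nitrogen in a ring: a number 6 percentage points lower from compound 1 to compound 2 (within the scatter). Since that swap between an aryl group and 3-(4-chlorophenyl)propyl stayed within the scatter, the return to an aryl group is expected to stay there as well, a number 4 percentage points higher from compound 2 to compound 3 (within the scatter). Compound 3 is therefore estimated at -72%, between -86% and -56%.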

Compound 3, a percentage reported as activity, at one concentration (the size of the read-out at that concentration, not a potency): -77%
Beside the measured number, compound 3's estimate is 5 percentage points above it; the measured number falls inside the stated range.
By their numbers in this assay, from the lowest: compounds 3, 2 and 1 (each within the scatter of the next).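

In this assay, 3-chlorophenyl in place of 3-(4-chlorophenyl)propyl on this amine nitrogen gives a number 1 percentage points lower from compound 2 to compound 3 (within the scatter) and so removing the propyl chain leaves the read-out unmoved. Changing only the ring's substituents, 3-chlorophenyl in place of 2-chloro-4-fluorophenyl, gives a number 7 percentage points lower from compound 1 to compound 3 (within the scatter) and so all three groups at this position read alike. Nothing available explains why these groups read alike. Still open, going by these compounds, is whether this holds for groups with no aromatic ring on that nitrogen, such as a plain methyl or a chain ending in a carboxylic acid.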